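The source may hold more compounds than are shown below. What is called first, only, known or untested is meant among the compounds shown, and "the series" means these compounds.

Compound 1 `O[C@@H]1[C@@H](O)[C@H](Oc2ccc3ccccc3c2)OC[C@H]1O`, tested in a functional assay on HCC70 cells (Homo sapiens) for antiproliferative activity, read by crystal violet staining, with a stated time of 96 h (a higher number here means that more compound is needed for the effect, a lower number that less compound is needed), gives 91 uM; 363 uM (2 entries), and the spread of those entries the several entries of compound 1 in this assay, 91 uM; 363 uM (2 entries) shows how much repeat measurements of this compound can wander. Compound 2 `O[C@H]1[C@H](Oc2ccc3ccccc3c2)OCC[C@@H]1O` gives 284 uM in this assay. Compound 3 `O[C@@H]1[C@@H](O)[C@H](Oc2ccc3ccccc3c2)OC[C@H]1F` gives 37 uM, the lowest number of the series; the only single-point step shown, a 7.7-fold lower number from compound 2 to compound 3 (0.89 log units; beyond the scatter), was fluoro in place of hydrogen on a saturated ring carbon. Compound 4 `CO[C@@H]1CO[C@@H](Oc2ccc3ccccc3c2)[C@H](O)[C@H]1O` has not been measured; it differs from compound 3 by methoxy in place of fluoro on a saturated ring carbon. No measured step exchanges fluoro for methoxy, so the one step shown bears only loosely. Compound 1, with hydroxy at that carbon, gives higher numbers than compound 3. Compound 4 is therefore expected to give 70 uM, within 20 uM to 250 uM, an estimated step of a 1.9-fold higher number from compound 3 to compound 4 (0.28 log units; within the scatter).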

Compound 4, concentration for half-maximal effect: 135 uM
For compound 4 the middle estimate is 1.9-fold (0.29 log units) below the measured one; measured number inside the range.
By their numbers in this assay, from the lowest: compound 3; then compound 4; then compound 2.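

In this assay the change from fluoro to methoxy at this carbon gives back part of what fluoro gained, with a 3.6-fold higher number from compound 3 to compound 4 (0.56 log units; beyond the scatter) at this position. Methoxy still keeps an advantage over hydrogen, with a 2.1-fold lower number from compound 2 to compound 4 (0.32 log units; beyond the scatter) on the same carbon, so this position accepts an oxygen-linked group and separates it from fluoro beyond the scatter. No order against the hydroxy of compound 1 can be given, since compound 4 at 135 uM falls inside the wide spread of the repeats: the several entries of compound 1 in this assay, 91 uM; 363 uM (2 entries).

From the compounds shown here alone, whether an amine or a longer chain such as ethoxy at this carbon would fall closer to fluoro or to hydrogen remains open.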